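Ester for Dimethoxy on the Benzyl Ether Arm

The compounds below may be only part of what the source reports. "The series", "measured", "known", "first", "only" and "open" are said of these compounds alone.

Compound 1, `COc1ccc(C(O)(Cc2ccc(C)cc2)c2cccc3ccccc23)c(OC)c1OC`, and compound 2, `COc1cc(COC(c2ccc(OC)c(OC)c2OC)c2cccc3ccccc23)cc(OC)c1`, were both examined in a functional assay on HCT-116 cells (Homo sapiens) for inhibition, read by sulforhodamine B assay, with a stated time of 48 h; a higher number here means a weaker inhibitor, a lower number a stronger inhibitor. In this assay compound 1 returns only the limit of > 20000 nM, a boundary of the measurement rather than a number. Compound 2 likewise returns only the limit of > 20000 nM, again not a number. Among the measured compounds shown here, compound 2 thus stands at the limit of > 20000 nM in this assay, at which 2 of the 2 values shown sit, and no measured step can be drawn from this pair. Compound 3, `COC(=O)c1ccc(COC(c2ccc(OC)c(OC)c2OC)c2cccc3ccccc23)cc1`, has not yet been measured in this assay. It differs from compound 2 by 4-(methoxycarbonyl)phenyl in place of 3,5-dimethoxyphenyl on a saturated chain carbon bound to an oxygen on a saturated carbon. For the measured compounds named here, with both measured compounds sitting at the limit there is no measured step to build on, and the change replaces one substituted phenyl with another of equal size. The expected step from compound 2 to compound 3 is a step that the limit leaves unreadable from compound 2 to compound 3, none beyond the scatter. Compound 3 is estimated at 25000 nM, within 8000 nM to 80000 nM, and is most likely to be reported once more only as a limit.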

Compound 3, half-maximal inhibitory concentration: > 20000 nM
Compound 3 ended at the assay's limit (the forecaster's own chance of this, stated with the estimate: 75%); the middle value is on the limit's open side.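

In this assay, among the compounds shown here, compound 3 returns only the limit > 20000 nM, a boundary of the measurement rather than a number, and no step from compound 2 to compound 3 can be read. The compounds shown leave open whether any change to the shared core gives a measurable inhibitory concentration.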